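A Second Chloro Step Expected on Compound 2

The source may report more compounds than this note shows. Statements on the series, on what has been measured and on what is new or still open speak of the compounds shown alone.

Three measured compounds share one core. Compound 3 `O=C(/C=C/c1ccccc1)c1ccco1` carries no substituent on its six-membered ring; in a functional assay on HL-60 cells (Homo sapiens) for inhibition, read by MTT assay, with a stated time of 48 h (on this read-out lower numbers stand for stronger inhibition and higher numbers for weaker inhibition), compound 3 gives 100000 nM. Compound 1 `O=C(/C=C/c1ccc(Cl)cc1)c1ccco1` carries a chloro group, and in this assay compound 1 gives 19000 nM. Compound 2 `O=C(/C=C/c1cccc([N+](=O)[O-])c1)c1ccco1` carries a nitro group, and in this assay compound 2 gives 14000 nM. The chloro change, (chloro in place of hydrogen on an aromatic carbon), produced a 5.3-fold lower number from compound 3 to compound 1 (0.72 log units; beyond the scatter). The nitro difference between the cores of compound 2 and compound 3 is nitro in place of hydrogen on an aromatic carbon, and removing it produced a 7.1-fold higher number from compound 2 to compound 3 (0.85 log units; beyond the scatter). Compound 1 and compound 2 lie within the scatter of each other.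

Compound 4 `O=C(/C=C/c1cc([N+](=O)[O-])ccc1Cl)c1ccco1` is not yet measured. It differs from compound 2 by chloro in place of hydrogen on an aromatic carbon. This is the same kind of change as from compound 3 to compound 1, but the place differs: in compound 1 the chloro is para to a group of 9 heavy atoms, whereas in compound 4 it is ortho to a group of 9 heavy atoms and para to a nitro group. In this assay the step is expected to be a 2.0-fold lower number from compound 2 to compound 4 (0.30 log units; within the scatter), smaller than a 5.3-fold lower number from compound 3 to compound 1 (0.72 log units; beyond the scatter). Among the measured compounds shown here, only that single chloro step supports the expectation. Compound 4 is expected to give 7000 nM, between 3000 nM and 18000 nM.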

Compound 4, half-maximal inhibitory concentration: 58000 nM
Compound 4: the middle estimate sits 8.3-fold (0.92 log units) below what was measured; measured number outside the range, above it.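

In this assay, chloro in place of hydrogen on an aromatic carbon gave a 4.1-fold higher number from compound 2 to compound 4 (0.62 log units; beyond the scatter), so in this series the change did not keep its direction when carried from one core to another. The two chloro steps differ by more than the scatter allows: the same change on two cores in this assay, a 5.3-fold lower number (0.72 log units; beyond the scatter) from compound 3 to compound 1 and a 4.1-fold higher number (0.62 log units; beyond the scatter) from compound 2 to compound 4, 22-fold (1.34 log units) apart, beyond the scatter of two such steps. This does not show why they differ, since the steps differ both in the chloro group's place and in the presence of the nitro group, and with one pair for each step the data cannot separate these two differences or support a rule for other cores.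

The compounds shown leave open whether a chloro group ortho to a group of 9 heavy atoms would also give a higher number on the core of compound 3, which lacks the nitro group. They also leave open how an amine or a methoxy group in place of the chloro would behave on either core.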